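Reshaping the hydroxy side chain of compound 3

A few compounds are considered here, and "the series" means these few. Any claim that something is new, unique, unknown or untested is made for them only; others in the source may bear on it.

In a functional assay on A2780 cells (Homo sapiens) for inhibition, read by sulforhodamine B assay, with a stated time of 96 h (on this read-out lower numbers stand for stronger inhibition of growth and higher numbers for weaker inhibition of growth), compound 1 `CC[C@@H](Nc1nc(NCc2ccccn2)c2ncn(C(C)C)c2n1)C(C)(C)O` gives 34000 nM, compound 2 `CC[C@@H](Nc1nc(NCc2ccccn2)c2ncn(C(C)C)c2n1)C(O)C(C)(C)C` gives 23000 nM and compound 3 `CC[C@H](Nc1nc(NCc2ccccn2)c2ncn(C(C)C)c2n1)C(C)(C)O` gives 19000 nM. All three numbers sit close together, and compound 3 lies within the scatter of both others: the steps are a 1.2-fold lower number from compound 2 to compound 3 (0.08 log units; within the scatter) and a 1.8-fold lower number from compound 1 to compound 3 (0.25 log units; within the scatter).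

Compound 4 `CCC(O)[C@H](CC)Nc1nc(NCc2ccccn2)c2ncn(C(C)C)c2n1` has the same atoms as compound 3, joined differently: 1-hydroxypropyl in place of 1-hydroxy-1-methylethyl on a saturated chain carbon bound to a nitrogen on an aromatic ring and a saturated chain carbon. Here 1-hydroxypropyl replaces 1-hydroxy-1-methylethyl on a saturated chain carbon bound to a nitrogen on an aromatic ring and a saturated chain carbon.

Two measured swaps of the group at this place bear most directly on the change. One is a 1.5-fold lower number from compound 1 to compound 2 (0.17 log units; within the scatter), and the other is the step from compound 2 to compound 3 given above. Both stayed within the scatter, and so did the change of configuration alone. No shift beyond the scatter is therefore expected, and the estimated step is a 1.2-fold higher number from compound 3 to compound 4 (0.06 log units; within the scatter). Compound 4 is expected at 22000 nM, within an estimated range of 10000 nM to 45000 nM.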

Compound 4, concentration for 50% growth inhibition: 21000 nM
The estimate for compound 4 lay 1.0-fold (0.02 log units) above the measured number; the range from low to high includes it.
By their numbers in this assay, from the lowest: compounds 3, 4, 2 and 1 (each within the scatter of the next).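

In this assay, rearranging the same atoms from 1-hydroxy-1-methylethyl into the unbranched 1-hydroxypropyl leaves the number within the scatter (a 1.1-fold higher number from compound 3 to compound 4 (0.04 log units; within the scatter)). The other two comparisons agree: 1-ethyl-2-hydroxybutyl in place of 1-ethyl-2-hydroxy-3,3-dimethylbutyl stays within the scatter (a 1.1-fold lower number from compound 2 to compound 4 (0.04 log units; within the scatter)), and so does 1-ethyl-2-hydroxybutyl in place of 1-(1-hydroxy-1-methylethyl)propyl (a 1.6-fold lower number from compound 1 to compound 4 (0.21 log units; within the scatter)). Across these four compounds, then, the shape of the hydroxy-bearing chain has shown no effect beyond the scatter, and the information given offers no reason for this.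

Going by these compounds, what remains open is whether this place responds to a change of the hydroxy group itself. An amine or a carboxylic acid in its position, or a plain propyl chain with no oxygen, would test that.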